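This account rests on a few compounds, and the source may have more. Where it says the series, first, only, none or still open, it means among the compounds named here.

Series notes. Compound 1 `CCCCCCCCCCn1cc(-c2nc3ccccc3cc2C)nn1` and compound 2 `CCCCCCCCCCn1cc(-c2nc3ccccc3cc2CC)nn1` share one core; compound 3 `CCCc1cc2ccccc2nc1-c1cn(CCC(F)(F)C(F)(F)C(F)(F)C(F)(F)C(F)(F)C(F)(F)C(F)(F)C(F)(F)F)nn1` and compound 4 `CCCCc1cc2ccccc2nc1-c1cn(CCC(F)(F)C(F)(F)C(F)(F)C(F)(F)C(F)(F)C(F)(F)C(F)(F)C(F)(F)F)nn1` share another, and the difference between the two cores is not broken down here. In a functional assay on U-937 cells (Homo sapiens) for cytotoxicity, read by MTT assay, with a stated time of 24 h (a lower number here means a stronger inhibitor, a higher number a weaker inhibitor), compound 1 gives only a limit, > 100 ug/mL. Compound 2 gives 12.7 ug/mL in this assay. The change methyl in place of hydrogen on a saturated chain carbon bound to an aromatic carbon yields an at least 7.8-fold lower number from compound 1 to compound 2 (0.89 log units; beyond the scatter), a step bounded by the limit of > 100 ug/mL in this assay, at which 2 of the 3 values shown sit, for compound 1. Compound 3 in this assay gives only a limit, > 100 ug/mL. Compound 4 carries the same kind of change, (methyl in place of hydrogen on a saturated chain carbon, three bonds along the chain from an aromatic carbon), though the place differs: here the chain carbon sits three bonds along the chain from an aromatic carbon, where in the earlier pair it is bound to an aromatic carbon. The step from compound 3 to compound 4 is expected at an at least 2.5-fold lower number from compound 3 to compound 4 (0.39 log units; beyond the scatter), smaller than the earlier one, because the step of an at least 7.8-fold lower number from compound 1 to compound 2 (0.89 log units; beyond the scatter) comes from a different core and a nearer place. Compound 4 is estimated at 40 ug/mL, with a range from 10 ug/mL to 100 ug/mL.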

Compound 4, half-maximal inhibitory concentration: 59.1 ug/mL
The estimate for compound 4 lay 1.5-fold (0.17 log units) below the measured number; measured number inside the range.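

In this assay, adding the methyl gives an at least 1.6-fold lower number from compound 3 to compound 4 (0.22 log units; that floor lies within the scatter). Both steps run in the same direction, which is all that can be said of carrying this change between the two cores; their sizes cannot be ranked, and the place of the change on the chain also differs between the pairs: the same change on two cores in this assay, an at least 7.8-fold lower number (0.89 log units; beyond the scatter) from compound 1 to compound 2 and an at least 1.6-fold lower number (0.22 log units; that floor lies within the scatter) from compound 3 to compound 4; the limit leaves it open whether they differ Both steps start from a limit of the assay rather than a number, so each gives only a floor: the limit of > 100 ug/mL in this assay, at which 2 of the 4 values shown sit.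

The compounds shown leave open how the change behaves on either core when both members of a pair give a number. Going by these compounds, it also remains open whether a longer chain, such as pentyl, would continue the step on either core.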